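Replacing a Methoxy Group with an Amino Group

A few compounds are considered here, and "the series" means these few. Any claim that something is new, unique, unknown or untested is made for them only; others in the source may bear on it.

Three related compounds have numbers in a functional assay on HCT-116 cells (Homo sapiens) for inhibition, read by MTT assay, with a stated time of 48 h; on this read-out lower numbers stand for stronger inhibition and higher numbers for weaker inhibition. Compound 1 (`COc1cc(-c2cc(-c3ccc(Cl)cc3)nc(-c3ccccc3)n2)cc(OC)c1OC`) gives 7980 nM, compound 2 (`COc1cc(-c2cc(-c3cccc(O)c3)nc(-c3ccccc3)n2)cc(OC)c1OC`) gives 20400 nM, and compound 3 (`COc1ccc(-c2cc(-c3cc(OC)c(OC)c(OC)c3)nc(-c3ccccc3)n2)cc1`) gives 4780 nM. Compound 3 sits at the low end of this small set together with compound 1, since the gap between them, a 1.7-fold lower number from compound 1 to compound 3 (0.22 log units; within the scatter), cannot separate the two. Compound 2 stands apart, with a 4.3-fold lower number from compound 2 to compound 3 (0.63 log units; beyond the scatter) and a 2.6-fold higher number from compound 1 to compound 2 (0.41 log units; beyond the scatter).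

The next compound, compound 4 (`COc1cc(-c2cc(-c3ccc(N)cc3)nc(-c3ccccc3)n2)cc(OC)c1OC`), differs from compound 3 in one place (amino in place of methoxy on an aromatic carbon). It has amino in place of methoxy on an aromatic carbon, para to a large group, so 4-methoxyphenyl becomes 4-aminophenyl. Among the compounds with values here, no measured step makes this exact swap, so the evidence is indirect. Two of the measured steps change this same aryl group, and the larger of them, a 4.3-fold lower number from compound 2 to compound 3 (0.63 log units; beyond the scatter), is still only modest. The other, a 1.7-fold lower number from compound 1 to compound 3 (0.22 log units; within the scatter), is small and closer to the present case, as both groups carry their substituent in the 4-position of the phenyl. The expected change in this assay is therefore small, with a slight lean toward a higher number: a 1.7-fold higher number from compound 3 to compound 4 (0.22 log units; within the scatter). For compound 4 the estimated value is 8000 nM, with an expected range from 3000 nM to 20000 nM.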

Compound 4, half-maximal inhibitory concentration: 12300 nM
Beside the measured number, compound 4's estimate is 1.5-fold (0.19 log units) below it, and the stated range covers the measured number.
By their numbers in this assay, from the lowest: compounds 3, 1, 4 and 2 (each within the scatter of the next, the first and the last beyond it).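

In this assay, the position para to a large group proves sensitive to the exchange of methoxy for amino, which gives a modest step beyond the scatter (a 2.6-fold higher number from compound 3 to compound 4 (0.41 log units; beyond the scatter)). The other two comparisons are less decisive: amino in place of chloro (a 1.5-fold higher number from compound 1 to compound 4 (0.19 log units; within the scatter)) and 4-aminophenyl in place of 3-hydroxyphenyl (a 1.7-fold lower number from compound 2 to compound 4 (0.22 log units; within the scatter)) both stay within the scatter, so neither pair can be put in order. The methoxy group therefore differs measurably from the amino group at this position, while the amino group cannot be distinguished from the chloro group there, and no accompanying measurement explains the methoxy-to-amino step.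

The compounds shown leave open whether a dimethylamino or acetylamino group at this position would give a number closer to that of compound 3 or to that of compound 4. They also leave open whether a hydroxy group at this same position would read differently from the 3-hydroxyphenyl group of compound 2, which would separate the effect of the group from the effect of where it sits.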